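This account rests on a few compounds, and the source may have more. Where it says the series, first, only, none or still open, it means among the compounds named here.

Compound 1 `NC(=O)CCC1CCN(c2nc(-c3cc(F)c(Cl)cc3F)nc3c2CS(=O)(=O)C3)CC1`: 0.3 mg/kg
Compound 2 `NC(=O)CN1CCN(c2nc(-c3cc(F)c(Cl)cc3F)nc3c2CS(=O)(=O)C3)CC1`: 3 mg/kg

In a functional assay on the whole organism (blood, strain ICR) with Mus musculus as the target, in the glucose tolerance test, with a stated time of 30 min (a lower number here means that less compound is needed, a higher number that more compound is needed for the effect), compound 2 gives the higher of the two numbers; the nearest, compound 1, sits at a lower number, a gap beyond the usual scatter. Compound 3 `CNC(=O)C1CCN(c2nc(-c3cc(F)c(Cl)cc3F)nc3c2CS(=O)(=O)C3)CC1` has not yet been measured. It differs from compound 2 in one place: 4-(methylcarbamoyl)piperidin-1-yl in place of 4-(carbamoylmethyl)piperazin-1-yl on an aromatic carbon. Within the data shown here, no measured pair shows exactly this change. The step of a 3.0-fold lower number from compound 2 to compound 3 (0.48 log units; beyond the scatter) is expected to lower the number beyond the scatter, because compound 1 gives 0.3 mg/kg with a related one-heteroatom ring. Compound 3 is therefore estimated at 1 mg/kg, with a range from 0.3 mg/kg to 3 mg/kg.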

Compound 3, minimum effective dose in the Mus musculus assay: 3 mg/kg
Estimate against measurement, compound 3: 3.0-fold (0.48 log units) below; the measured number falls inside the stated range.
By their numbers in the Mus musculus assay, from the lowest: compound 1; then compounds 2 and 3 (each within the scatter of the next).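

In the Mus musculus assay the swap to 4-(methylcarbamoyl)piperidin-1-yl on this aromatic carbon changes nothing beyond the scatter (no change at the digits printed from compound 2 to compound 3 (within the scatter)), so the ring change alone does not reach the lower number of compound 1, whereas the step of methylcarbamoyl in place of 2-carbamoylethyl on a saturated ring carbon is large (a 10-fold higher number from compound 1 to compound 3 (1.00 log units; beyond the scatter)). In a physicochemical assay for solubility, with a stated time of 20 h, at pH 6.8 (on this read-out lower numbers stand for lower solubility and higher numbers for higher solubility), compound 2 gives > 100000 nM as a limit of the assay, not a number. In the physicochemical assay compound 3 gives 11000 nM as a measured number, so the swap is not neutral on this read-out (an at least 9.0-fold lower number from compound 2 to compound 3 (0.95 log units; beyond the scatter)). Open, going by these compounds, is how a carboxylic acid or an amine at the end of that chain, or a longer chain, would read in either assay.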